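This account rests on a few compounds, and the source may have more. Where it says the series, first, only, none or still open, it means among the compounds named here.

Of the compounds shown here, three have been tested so far in an ADME assay on HEK293 cells (Homo sapiens) for cytotoxicity, read by MTT assay; a lower number here means a stronger inhibitor, a higher number a weaker inhibitor. Compound 2 `O=c1n(Cc2cn(Cc3cc4ccc(Cl)cc4nc3Cl)nn2)cnn1-c1ccccc1` gives 869 ug/mL, the highest of the three numbers. Compound 3 `Cc1ccc2nc(Cl)c(Cn3cc(Cn4cnn(-c5ccccc5)c4=O)nn3)cc2c1` gives 478 ug/mL in this assay, a value within the scatter of compound 2. Compound 1 `COc1ccc(-n2ncn(Cc3cn(Cc4cc5cc(Br)ccc5nc4Cl)nn3)c2=O)cc1` gives 333 ug/mL in this assay, a lower number than compound 2 by more than the scatter. The next compound, compound 4 `O=c1n(Cc2cn(Cc3cc4ccccc4nc3Cl)nn2)cnn1-c1ccccc1`, differs from compound 2 by one change: hydrogen in place of chloro on an aromatic carbon. Among the compounds with values here, no measured pair shows a change of this kind, so the size of the step is uncertain; a step no larger than the scatter, in either direction, seems most likely. Compound 4 is therefore expected to give about 900 ug/mL in this assay, in a range from 450 ug/mL to 1800 ug/mL, which means an expected step of a 1.0-fold higher number from compound 2 to compound 4 (0.02 log units; within the scatter).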

Compound 4, half-maximal inhibitory concentration: 655 ug/mL
Estimate against measurement, compound 4: 1.4-fold (0.14 log units) above, within the range that was stated.
By their numbers in this assay, from the lowest: compounds 1, 3, 4 and 2 (each within the scatter of the next, the first and the last beyond it).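

In this assay the step is a 1.3-fold lower number from compound 2 to compound 4 (0.12 log units; within the scatter) with hydrogen in place of chloro, and a 1.4-fold higher number from compound 3 to compound 4 (0.14 log units; within the scatter) with hydrogen in place of methyl. On this evidence, neither chloro nor methyl on the six-membered aromatic ring of carbon only can be told apart from hydrogen, since both steps stay within the scatter. No measurement here offers an explanation for this result. Still open, as far as these compounds go, is whether an amine or a carboxylic acid on this ring would give a step beyond the scatter.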